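The source may hold more compounds than are shown below. What is called first, only, known or untested is meant among the compounds shown, and "the series" means these compounds.

Measured in a functional assay on HepG2 cells (Homo sapiens) for antiproliferative activity, read by MTT assay, with a stated time of 72 h; a higher number here means a weaker inhibitor, a lower number a stronger inhibitor:
- compound 1 `COc1ccc(N2C(=O)COc3ccc(-c4ccc(O)cc4)cc32)cc1`: 10800 nM
- compound 2 `COc1cccc(N2C(=O)COc3ccc(-c4ccc(O)cc4)cc32)c1`: 26100 nM

Compound 2 has the higher of the two numbers, at 26100 nM, and so is the weaker inhibitor of the pair. Compound 3 `O=C1COc2ccc(-c3ccc(O)cc3)cc2N1` is next, with this change from compound 2: hydrogen in place of 3-methoxyphenyl on an amide-type nitrogen in a ring. In words, hydrogen stands in place of 3-methoxyphenyl on an amide-type nitrogen in a ring.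

Going by the values given here, only one measured step bears on this: a 2.4-fold higher number from compound 1 to compound 2 (0.38 log units; beyond the scatter). It is modest and exchanges one methoxyphenyl group for another. Among the compounds with values here, no measured compound has hydrogen at this place, so the size of the new step is poorly fixed. As far as these compounds go, a modest step in this assay is expected, more likely towards a higher number, though the direction remains open. The expected step is a 1.7-fold higher number from compound 2 to compound 3 (0.24 log units; within the scatter). For compound 3 the estimated value is 45000 nM, with an expected range of 15000 nM to 120000 nM.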

Compound 3, half-maximal inhibitory concentration: 38200 nM
Estimate against measurement, compound 3: 1.2-fold (0.07 log units) above; low and high end bracket the measured number.
By their numbers in this assay, from the lowest: compound 1; then compounds 2 and 3 (each within the scatter of the next).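

Hydrogen in place of 3-methoxyphenyl on the amide-type nitrogen in a ring leaves the reading in this assay within the scatter (a 1.5-fold higher number from compound 2 to compound 3 (0.17 log units; within the scatter)), so the aryl group of compound 2 shows no measurable gain over hydrogen at this place. Hydrogen in place of 4-methoxyphenyl is a step beyond the scatter (a 3.5-fold higher number from compound 1 to compound 3 (0.55 log units; beyond the scatter)), so among the three compounds only the 4-methoxyphenyl group of compound 1 separates from hydrogen here. Nothing at hand gives a reason for this difference between the two methoxyphenyl groups.

Still open, as far as these compounds go, is how a methyl group, a longer alkyl chain or an amine-bearing chain on this nitrogen would read in this assay. Also open, from the compounds shown here alone, is whether the separation of 4-methoxyphenyl from hydrogen holds when another part of the core of compound 1 is changed.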